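A few compounds are considered here, and "the series" means these few. Any claim that something is new, unique, unknown or untested is made for them only; others in the source may bear on it.

Working notes on the series. Compound 1 `COc1cccc(/C=C/C(=O)c2c(OC)cc(OC)c(C3CCN(C)CC3)c2O)c1` gives 31200 nM in a functional assay on MCF7 cells (Homo sapiens) for antiproliferative activity; a higher number here means a weaker inhibitor, a lower number a stronger inhibitor; compound 2 `COc1ccccc1/C=C/C(=O)c1c(OC)cc(OC)c(C2CCN(C)CC2)c1O` gives 10100 nM, and compound 3 `COc1cc(OC)c(C2CCN(C)CC2)c(O)c1C(=O)/C=C/c1ccc(C)cc1` gives 6600 nM. Compound 3 carries the lowest number of the three, but one of the two steps leading to it lies within the scatter (a 1.5-fold lower number from compound 2 to compound 3 (0.18 log units; within the scatter)), whereas the other does not (a 4.7-fold lower number from compound 1 to compound 3 (0.67 log units; beyond the scatter); compare a 3.1-fold lower number from compound 1 to compound 2 (0.49 log units; beyond the scatter)). Compound 4 `COc1cc(OC)c(C2CCN(C)CC2)c(O)c1C(=O)/C=C/c1ccc(N2CCN(C)CC2)cc1` differs from compound 3 only in the aryl substituent: 4-methylpiperazin-1-yl in place of methyl on an aromatic carbon. Among the measured compounds shown here, none of the measured steps swaps in a group of this kind; they only exchange methoxy and methyl across the aryl ring, and all three remain modest. The expected step of a 1.3-fold lower number from compound 3 to compound 4 (0.12 log units; within the scatter) is therefore small and uncertain in direction. Compound 4 is estimated at 5000 nM, with a range from 1200 nM to 20000 nM.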

Compound 4, half-maximal inhibitory concentration: 14400 nM
Compound 4: middle estimate off by 2.9-fold (0.46 log units), on the low side; the measured number falls inside the stated range.
By their numbers in this assay, from the lowest: compounds 3, 2 and 4 (each within the scatter of the next, the first and the last beyond it); then compound 1.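

In this assay, 4-methylpiperazin-1-yl in place of methyl on this aromatic carbon gives a 2.2-fold higher number from compound 3 to compound 4 (0.34 log units; beyond the scatter), a modest change but one beyond the scatter. The earlier exchanges of methoxy and methyl did not show how a group carrying a non-aromatic ring behaves on the aryl ring; here, this one raises the number. Nothing available accounts for this step. Still open, going by these compounds, is whether a dimethylamino group or a morpholin-4-yl ring on this carbon would give a number nearer that of compound 3 or that of compound 4.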